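The source may report more compounds than this note shows. Statements on the series, on what has been measured and on what is new or still open speak of the compounds shown alone.

Compound 1 `O=C(C/C=C/c1ccccc1)Nc1nc2ccccc2c(=O)s1`: 158 nM
Compound 2 `COc1cccc(C#CC(=O)Nc2nc3ccccc3c(=O)s2)c1`: > 1000 nM
Compound 3 `COc1cccc(/C=C/C(=O)Nc2nc3ccccc3c(=O)s2)c1`: > 1000 nM

All three compounds share the same core and differ only in the group carried on the amide. In an assay on CHO cells for displacement of a labelled ligand from adenosine receptor A3 (Homo sapiens), read by scintillation counting, with a stated time of 60 min (a lower number here means a stronger inhibitor, a higher number a weaker inhibitor), compound 1 gives 158 nM, a measured number. Compound 2 reaches only > 1000 nM, which is a limit of the assay and not a number. Compound 3 likewise stops at > 1000 nM, again a limit and not a number. Compound 3 therefore stands at the weak end of what has been measured, resting at the limit of > 1000 nM in this assay, at which 2 of the 3 values shown sit. Among the measured compounds shown here, no two measured compounds differ in a single place, so no measured step can be read off, and the methoxy-bearing compound 3 only tells that binding was too weak to be quantified.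

Compound 4 `O=C(/C=C/c1cccc(Cl)c1)Nc1nc2ccccc2c(=O)s1` has not yet been measured. It differs from compound 3 by chloro in place of methoxy on an aromatic carbon. With compound 3 known only as a limit, there is no measured number to anchor the change, and the step that the limit leaves unreadable from compound 3 to compound 4 is expected to be modest, most likely toward somewhat stronger binding but not with confidence beyond the scatter. Compound 4 is estimated to give 1500 nM, within a range from 400 nM to 6000 nM, with a real chance that the assay again reports only a limit.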

Compound 4, inhibition constant: > 1000 nM
Compound 4 gave a limit, no number; the forecaster's own chance of this, stated with the estimate: 55%; the middle value is on the limit's open side.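

Compound 4 stops at > 1000 nM, a limit and not a number. Compound 3 also rests at a limit, so no step can be read between compound 3 and compound 4: the limit of > 1000 nM in this assay, at which 3 of the 4 values shown sit. The compounds shown leave open how strongly either of these two binds, and whether chloro or methoxy serves better on the aromatic ring.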